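A few compounds are considered here, and "the series" means these few. Any claim that something is new, unique, unknown or untested is made for them only; others in the source may bear on it.

In a functional assay on HCT-116 cells (Homo sapiens) for inhibition, read by CCK-8 assay, with a stated time of 48 h (on this read-out higher numbers stand for weaker inhibition and lower numbers for stronger inhibition), compound 1 (`COc1cc(-c2ccnc3cc(-c4ccc(C)c(C)c4)nn23)cc(OC)c1OC`) gives 261 nM and compound 2 (`COc1ccc(-c2cc3nccc(-c4cc(OC)c(OC)c(OC)c4)n3n2)cc1`) gives 404 nM. These two values lie within the usual scatter of each other, so compound 2 cannot be told apart from compound 1 on these numbers. The two compounds share a core and differ in one aromatic group, and that exchange produced a 1.5-fold higher number from compound 1 to compound 2 (0.19 log units; within the scatter).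

Compound 3 (`COc1cc(-c2ccnc3cc(-c4ccc5cnn(C)c5c4)nn23)cc(OC)c1OC`) keeps the shared core and changes the group at that same place: 1-methyl-1H-indazol-6-yl in place of 4-methoxyphenyl on an aromatic carbon. In words, 1-methyl-1H-indazol-6-yl stands in place of 4-methoxyphenyl on an aromatic carbon, so a single ring gives way to a group of two rings. For the measured compounds named here, the one measured exchange at this place is the only guide, and it stayed within the scatter. Going by the values given here, no measured compound yet carries a two-ring group here, so the forecast remains uncertain.

In this assay, the expected change is a 1.8-fold lower number from compound 2 to compound 3 (0.26 log units; within the scatter), a modest estimated move that does not go beyond the scatter. For compound 3 the expected value is 220 nM, with an estimated range from 45 nM to 800 nM.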

Compound 3, half-maximal inhibitory concentration: 2440 nM
Estimate against measurement, compound 3: 11-fold (1.04 log units) below; measured number outside the range, above it.
By their numbers in this assay, from the lowest: compounds 1 and 2 (each within the scatter of the next); then compound 3.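

In this assay, this position does not treat every aromatic group alike: the two single-ring groups, 3,4-dimethylphenyl and 4-methoxyphenyl, could not be told apart, whereas 1-methyl-1H-indazol-6-yl gives a 6.0-fold higher number from compound 2 to compound 3 (0.78 log units; beyond the scatter) and a 9.3-fold higher number from compound 1 to compound 3 (0.97 log units; beyond the scatter). For the compounds shown here, both steps lie beyond the scatter, so this is the first exchange here that clearly changes the result, and it points towards weaker inhibition, showing that the choice of aromatic group at this place can matter in these cells. Nothing available explains this loss, and a single two-ring example does not establish a rule for two-ring groups in general.

The entering group differs from the single-ring groups in several ways at once, so these compounds cannot show whether the second ring, the two ring nitrogens or the methyl on nitrogen accounts for the change. Going by these compounds, a comparison with naphthalen-2-yl, which has two rings and no nitrogen, or with 1H-indazol-6-yl, which lacks that methyl, would help to separate these features, while a phenyl ring carrying an amine or a carboxylic acid remains unexplored here.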